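The source may hold more compounds than are shown below. What is called first, only, known or untested is meant among the compounds shown, and "the series" means these compounds.

Working notes on the series, starting from compound 3 `O=C1C=C(Nc2ccccc2)C(=O)c2c1nc1n2[C@H]2OC[C@@H](O)[C@H]2OC1`. In a functional assay on MCF7 cells (Homo sapiens) for inhibition, read by sulforhodamine B assay (on this read-out higher numbers stand for weaker inhibition and lower numbers for stronger inhibition), compound 3 gives > 4000 nM, which is a limit and not a number. Compound 2 `COc1ccccc1NC1=CC(=O)c2nc3n(c2C1=O)[C@H]1OC[C@@H](O)[C@H]1OC3` gives > 4000 nM in this assay, also a limit. Compound 1 `O=C1C=C(N2CCC2)C(=O)c2c1nc1n2[C@H]2OC[C@@H](O)[C@H]2OC1` gives > 16000 nM in this assay, again a limit. Compound 3 therefore has no readable rank among the three.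

The next compound is compound 4 `COc1cccc(NC2=CC(=O)c3nc4n(c3C2=O)[C@H]2OC[C@@H](O)[C@H]2OC4)c1`. It differs from compound 3 by methoxy in place of hydrogen on an aromatic carbon, with methoxy in place of hydrogen on an aromatic carbon of a six-membered aromatic ring of carbon only, meta to a large group. The anilino of compound 3 thus becomes (3-methoxyphenyl)amino.

The closest measured change is a step that the two limits leave unreadable from compound 2 to compound 3, where hydrogen replaces the methoxy of a (2-methoxyphenyl)amino group, so it concerns the same group at another place on the ring. Its size cannot be read. The same is true of a step that the two limits leave unreadable from compound 1 to compound 2 and of a step that the two limits leave unreadable from compound 1 to compound 3. Among the measured compounds shown here, no measured step supports a shift in either direction.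

The expected change, a step that the limit leaves unreadable from compound 3 to compound 4, is therefore none beyond the scatter. Compound 4 is expected to read about 5000 nM, with an estimated range of 2000 nM to 16000 nM, and may well be reported only as a limit.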

Compound 4, half-maximal inhibitory concentration: > 4000 nM
Compound 4 was reported as a limit; the forecaster's own chance of this, stated with the estimate: 75%; the middle value is on the limit's open side.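

Compound 4 gives > 4000 nM in this assay, which is a limit and not a number. The steps to compound 4 from compound 1, compound 2 and compound 3 therefore cannot be read. The compounds shown leave open how the methoxy position, or anilino against azetidin-1-yl, changes inhibition in this assay, since none gives a readable value.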